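The source may report more compounds than this note shows. Statements on the series, on what has been measured and on what is new or still open speak of the compounds shown alone.

Compound 1 `COc1cc(N(Cc2nc3ccccc3[nH]2)S(=O)(=O)c2ccccc2)cc(OC)c1OC` gives 25500 nM in a functional assay on PC-3 cells (Homo sapiens) for inhibition, read by MTT assay, with a stated time of 48 h; a higher number here means a weaker inhibitor, a lower number a stronger inhibitor. Compound 2 `Cc1ccc(S(=O)(=O)N(Cc2nc3ccccc3[nH]2)c2ccc(F)cc2)cc1` gives 45000 nM in this assay. Compound 3 `Cc1ccc(S(=O)(=O)N(Cc2nc3ccccc3[nH]2)c2ccc(Cl)cc2)cc1` gives 42200 nM in this assay.

All three numbers sit close together: compound 3 is separated from compound 2 and from compound 1 by less than the usual scatter of this assay, so none of the three can be set apart from the others. Among the compounds with values here, the only single-point step among them is a 1.1-fold lower number from compound 2 to compound 3 (0.03 log units; within the scatter), a change of halogen that left the number essentially where it was.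

Compound 4 `Cc1ccc(S(=O)(=O)N(Cc2nc3ccccc3[nH]2)c2ccccc2)cc1` differs from compound 3 by hydrogen in place of chloro on an aromatic carbon. Within the data shown here, the one measured step that bears on this position, a 1.1-fold lower number from compound 2 to compound 3 (0.03 log units; within the scatter), did not move the number beyond the scatter, and nothing among the three compounds suggests that removing the halogen altogether should do more. The step expected is therefore a 1.1-fold higher number from compound 3 to compound 4 (0.03 log units; within the scatter), no shift beyond the scatter in either direction. On that basis compound 4 is estimated at 45000 nM in this assay, with a range from 20000 nM to 110000 nM.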

Compound 4, half-maximal inhibitory concentration: > 50000 nM
Compound 4: only a limit was reported (the forecaster's own chance of this, stated with the estimate: 20%); middle value at least 1.1-fold (0.04 log units) away from the limit.
By their numbers in this assay, from the lowest: compounds 1, 3 and 2 (each within the scatter of the next). At a limit, above all of these: compound 4.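

Compound 4 is reported only as a limit and not as a number: the limit of > 50000 nM in this assay, at which 1 of the 4 values shown sits. Taking the halogen off this position, para to a large group, gives an at least 1.1-fold higher number from compound 3 to compound 4 (0.07 log units; that floor lies within the scatter), and measured against the fluoro compound it gives an at least 1.1-fold higher number from compound 2 to compound 4 (0.04 log units; that floor lies within the scatter). Where the exchange of one halogen for the other could be read as a number, the change from 4-chlorophenyl to phenyl yields only a floor, so the earlier compounds' near-identical values are now joined by a compound that cannot be shown to differ from them, while a real loss on removing the halogen is not excluded either.

From the compounds shown here alone, how far the true value of compound 4 lies from those of compound 2 and compound 3 stays open. Also open, going by these compounds, is how an amine or a carboxylic acid at this position would read in this assay.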